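From Bromine to Nitro: What the Next Number Might Be

This account rests on a few compounds, and the source may have more. Where it says the series, first, only, none or still open, it means among the compounds named here.

Of the compounds shown here, three built on one shared core have been tested in a toxicity assay on the whole organism with Rattus norvegicus as the target, at a dose of 200 mg/kg by the oral route; on this read-out higher numbers stand for a stronger effect at the one dose given and lower numbers for a weaker effect. Compound 1, `Brc1ccccc1OCC1=NCCO1`, gives 90%, the highest number among the three, although the gap to compound 2 lies within the usual scatter. Compound 2, `Brc1ccc(OCC2=NCCO2)cc1`, gives 80% in this assay, and compound 3, `Fc1ccc(OCC2=NCCO2)cc1`, gives 40%. For the measured compounds named here, the only step that can be traced between two measured compounds is a number 40 percentage points lower from compound 2 to compound 3 (beyond the scatter), a swap of one halogen for another.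

Compound 4, `O=[N+]([O-])c1ccccc1OCC1=NCCO1`, has not yet been measured. It differs from compound 1 by nitro in place of bromo on an aromatic carbon. Going by the values given here, no measured step exchanges bromo for nitro, so the only guide is the halogen swap from compound 2 to compound 3, which moved the number a long way. With that single guide, the expected step is a number 30 percentage points lower from compound 1 to compound 4 (beyond the scatter), downward but with wide uncertainty. Compound 4 is therefore estimated at 60% in this assay, with a range from 30% to 90%.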

Compound 4, a percentage reported as activity, at one dose (the size of the read-out at that dose, not a potency): 55%
For compound 4 the middle estimate is 5 percentage points above the measured one; the range from low to high includes it.
By their numbers in this assay, from the lowest: compound 3; then compound 4; then compounds 2 and 1 (each within the scatter of the next).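

At the aromatic carbon ortho to a group of 7 heavy atoms, nitro in place of bromo gives a number 35 percentage points lower from compound 1 to compound 4 (beyond the scatter) in this assay. For the compounds shown here, the earlier large step was an exchange of one halogen for another, on compounds whose halogen stands elsewhere on the aromatic ring, so this is the first sign that the read-out also responds strongly at this place, and to a change from a single bromine atom to a group of three heavy atoms with two hydrogen-bond acceptors. Nothing available explains why the number falls with this change.

Going by these compounds, whether an amine or a methoxy group at this same place would stay close to compound 1 or fall as far as compound 4 remains open. Also open, on these data alone, is how nitro would behave at the halogen's place in compound 2.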